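Acid in place of benzyl ester on the stilbene arm

A few compounds are considered here, and "the series" means these few. Any claim that something is new, unique, unknown or untested is made for them only; others in the source may bear on it.

Compound 1 `COC(=O)/C=C/c1cccc(N(Cc2ccc(/C=C/c3ccccn3)cc2)C(=O)C2CCCCC2)c1` gives 309 nM in an assay on isolated protein with Bile acid receptor (Homo sapiens) as the target; on this read-out higher numbers stand for an effect only at larger amounts of compound and lower numbers for an effect already at smaller amounts. Compound 2 `COC(=O)/C=C/c1cccc(N(Cc2ccc(/C=C/C(=O)OCc3ccccc3)cc2)C(=O)C2CCCCC2)c1` reaches only the limit of > 1000 nM in this assay, so for compound 2 no number is known, only that limit. Among the measured compounds shown here, the one measured step, an at least 3.2-fold higher number from compound 1 to compound 2 (0.51 log units; beyond the scatter), is the sole comparison available, and it concerns a different change; it sets compound 2 at the limit of > 1000 nM in this assay, at which 1 of the 2 values shown sits. Compound 3 `COC(=O)/C=C/c1cccc(N(Cc2ccc(/C=C/C(=O)O)cc2)C(=O)C2CCCCC2)c1` differs from compound 2 by hydrogen in place of benzyl on an oxygen next to a carbonyl group. No measured pair shows this change, and the starting point is itself a limit, so the direction of the step from compound 2 to compound 3 cannot be read from the shown values. As a working expectation, compound 3 is estimated near 1500 nM in this assay, within 300 nM to 8000 nM. The expected step that the limit leaves unreadable from compound 2 to compound 3 is therefore small relative to the limit, with a real chance that compound 3 again returns only a limit.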

Compound 3, half-maximal effective concentration: > 1000 nM
Compound 3 ended at the assay's limit; the forecaster's own chance of this, stated with the estimate: 55%; the middle value lies beyond the limit too.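

In this assay compound 3 also returns only a limit, > 1000 nM. Carboxy in place of pyridin-2-yl gives an at least 3.2-fold higher number from compound 1 to compound 3 (0.51 log units; beyond the scatter), so on this arm the carboxy end, like the benzyloxycarbonyl end, does not retain the reading of compound 1. The step between compound 2 and compound 3 cannot be read, and neither end gives a number in this series: the limit of > 1000 nM in this assay, at which 2 of the 3 values shown sit.

Going by these compounds, the actual values of compound 2 and compound 3 remain unknown, so benzyloxycarbonyl and carboxy cannot be ranked against each other. Also open, on these data alone, is whether a phenyl ring, a primary amide or an amine at the end of this arm would return a number close to that of compound 1, and so how specific the reading is to pyridin-2-yl.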